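The source may report more compounds than this note shows. Statements on the series, on what has been measured and on what is new or still open speak of the compounds shown alone.

In an ADME assay on microsomes from liver (Homo sapiens) for metabolic stability, using NADPH, with a stated time of 10 min (on this read-out lower numbers stand for a less stable compound and higher numbers for a more stable compound), compound 1 `CN(C)[C@H]1CCN(c2cccc3c2C[C@H](CN(C)[C@H]2CCCc4cccnc42)NC3)C1` gives 67.5% and compound 3 `CN1CCN(Nc2cccc3c2C[C@@H](CN(C)[C@H]2CCCc4cccnc42)NC3)CC1` gives 73.6%, two numbers within the usual scatter of each other. Compound 2 `CN(C)[C@@H]1CCN(c2cccc3c2C[C@H](CN(C)[C@H]2CCCc4cccnc42)NC3)C1` differs from compound 1 only in the configuration as drawn, and for compound 2 the entry reads "not determined" (no result reported). Compound 4 `CN(C[C@H]1Cc2c(cccc2N2C[C@H]3CCN(C)[C@H]3C2)CN1)[C@H]1CCCc2cccnc21` keeps the core of compound 1 but replaces the 3-(dimethylamino)pyrrolidin-1-yl group on an aromatic carbon with a group holding two five-membered non-aromatic rings: a group of 9 heavy atoms (7 carbon, 2 nitrogen; 2 five-membered non-aromatic rings with 1 hetero atom each) in place of a group of 8 heavy atoms (6 carbon, 2 nitrogen; one five-membered non-aromatic ring with 1 hetero atom), on an aromatic carbon. Among the measured compounds shown here, no measured pair shows a change of this kind, so only a modest shift is expected, none beyond the scatter. The estimated change is small, a number 1.5 percentage points lower from compound 1 to compound 4 (within the scatter). Compound 4 is expected to give 66%, with an estimated range from 48% to 82%.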

Compound 4, percent of the compound remaining: 97.6%
For compound 4 the middle estimate is 31.6 percentage points below the measured one, outside the stated range (above it).
By their numbers in this assay, from the lowest: compounds 1 and 3 (each within the scatter of the next); then compound 4.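

In this assay, swapping 3-(dimethylamino)pyrrolidin-1-yl for the group with two five-membered non-aromatic rings gives a number 30.1 percentage points higher from compound 1 to compound 4 (beyond the scatter). This is the first step shown at this aromatic carbon, and it shows that the group placed there can move this read-out well beyond the scatter. Nothing shown explains why this swap has so large an effect. On these data alone, it remains open whether the mirror-image arrangement of the entering group would give a similar number. As far as these compounds go, it also remains open how a simpler group, such as a morpholine ring, would behave at this place.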